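Removing a Methyl from the Ring Nitrogen

The source may report more compounds than this note shows. Statements on the series, on what has been measured and on what is new or still open speak of the compounds shown alone.

Measured so far:
compound 1 `CCC(=O)N1CC2(CC(NC(=O)c3cc(-c4ccccc4)no3)C2)C1` gives 69%
compound 2 `CN(C)C(=O)CCN1CCc2c(cc(-c3ccc(F)cc3)n2C)C1=O` gives 42%
compound 3 `CN(C)C(=O)CCNC(=O)c1cc(-c2ccc(F)cc2)no1` gives 10%

These three compounds were tested in an ADME assay on microsomes from liver (Macaca mulatta) for metabolic stability, with a stated time of 0.5 h, tested at 0.5 mg/mL; on this read-out higher numbers stand for a more stable compound and lower numbers for a less stable compound. Compound 2 stands second highest of the three numbers. Its nearest neighbour is compound 1, which stands higher by a gap beyond the usual scatter; its furthest is compound 3, which stands lower, again beyond the scatter. Within the data shown here, no two of the measured compounds differ in only one place, so no measured step points the way for a single change.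

The next compound, compound 4 `CN(C)C(=O)CCN1CCc2[nH]c(-c3ccc(F)cc3)cc2C1=O`, differs from compound 2 in one spot: hydrogen in place of methyl on an aromatic nitrogen. The change is the replacement of one methyl by a hydrogen. A step of modest size is expected, most likely not beyond the scatter, with a slight lean upward. The estimated step is a number 8 percentage points higher from compound 2 to compound 4 (within the scatter). Compound 4 is therefore expected to give about 50%, within a range from 30% to 72%.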

Compound 4, percent of the compound remaining: 39%
The estimate for compound 4 lay 11 percentage points above the measured number; low and high end bracket the measured number.
By their numbers in this assay, from the lowest: compound 3; then compounds 4 and 2 (each within the scatter of the next); then compound 1.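

Among these compounds, compounds 2 and 4 form the only pair here that differs in one place, so they give the first direct reading of a single change: hydrogen in place of methyl on the aromatic nitrogen. In this assay the step is a number 3 percentage points lower from compound 2 to compound 4 (within the scatter), which means this methyl can be exchanged for hydrogen while the two numbers remain within the usual scatter of each other. No available information explains this result.

As far as these compounds go, this single pair covers only methyl and hydrogen, so it remains open how an ethyl group, a longer chain or a chain ending in an amine would read on that nitrogen. Also open, from the compounds shown here alone, is whether a carboxylic acid in place of the dimethylamide end of the side chain would leave the number within the scatter.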